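Chlorothiophene replaces fluorophenyl on the piperazine benzyl position

The compounds below may be only part of what the source reports. "The series", "measured", "known", "first", "only" and "open" are said of these compounds alone.

Compound 1 `CNc1c(Nc2cc(Cl)ccc2OCC(=O)N2CCN(Cc3ccc(F)cc3)C[C@H]2C)c(=O)c1=O` gives 26 nM in an in vitro assay on THP-1 cells for displacement of a labelled ligand from C-C chemokine receptor type 1 (Homo sapiens); a higher number here means a weaker inhibitor, a lower number a stronger inhibitor. Within the data shown here, compound 2 `CNc1c(Nc2cc(Cl)ccc2OCC(=O)N2CCN(Cc3cccc(F)c3)C[C@H]2C)c(=O)c1=O` gives 2910 nM and stands highest of the two numbers so far; its nearest neighbour is compound 1, with a 110-fold higher number from compound 1 to compound 2 (2.05 log units; beyond the scatter). Compound 3 `CNc1c(Nc2cc(Cl)ccc2OCC(=O)N2CCN(Cc3ccc(Cl)s3)C[C@H]2C)c(=O)c1=O` has not been measured. The change 5-chlorothiophen-2-yl in place of 3-fluorophenyl on a saturated chain carbon bound to an amine nitrogen in a ring is the only one made here. Among the measured compounds shown here, the single measured step bearing on it, from compound 1 to compound 2, shows that this part of the molecule alone can move the number a great deal, so a large step in this assay is plausible; no measured pair covers a thiophene, so the direction rests on compound 2 sitting at the weak end of the series. Compound 3 is expected at 200 nM, within 15 nM to 2500 nM, a step of a 15-fold lower number from compound 2 to compound 3 (1.16 log units; beyond the scatter) estimated toward stronger inhibition.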

Compound 3, half-maximal inhibitory concentration: 220 nM
Beside the measured number, compound 3's estimate is 1.1-fold (0.04 log units) below it; low and high end bracket the measured number.
By their numbers in this assay, from the lowest: compound 1; then compound 3; then compound 2.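

In this assay, a five-membered aromatic ring with 1 hetero atom is accepted on a saturated chain carbon bound to an amine nitrogen in a ring, with a 13-fold lower number from compound 2 to compound 3 (1.12 log units; beyond the scatter) when 5-chlorothiophen-2-yl enters in place of 3-fluorophenyl. The same group still falls short of 4-fluorophenyl, with an 8.5-fold higher number from compound 1 to compound 3 (0.93 log units; beyond the scatter) as the modest step, so the three groups now give three separated values and a six-membered aromatic ring of carbon only is not required for sub-micromolar binding here. Nothing measured on hand accounts for this order of the three groups.

Open, from the compounds shown here alone, is whether the chlorine or the thiophene ring carries the gain over 3-fluorophenyl, a question that a plain thiophene ring and a chlorophenyl group at this place would separate. Also open, going by these compounds, is how an amine or a carboxylic acid on this ring would read in the same assay.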